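This account rests on a few compounds, and the source may have more. Where it says the series, first, only, none or still open, it means among the compounds named here.

Compound 1, `Cc1ccc2c(c1)[n+]([O-])c(C#N)c(-c1ccco1)[n+]2[O-]`, measured at 0.845.
Compound 2, `N#Cc1c(-c2ccco2)[n+]([O-])c2ccc(C(F)(F)F)cc2[n+]1[O-]`, measured at 1.5.
Compound 3, `COc1ccc(-c2c(C#N)[n+]([O-])c3cc(C)ccc3[n+]2[O-])cc1`, measured at 1.83.

These three compounds were all examined in a physicochemical assay for lipophilicity, measured as octanol-water partition; on this read-out higher numbers stand for higher lipophilicity and lower numbers for lower lipophilicity. Compounds 1 and 2 share a core and differ in one place: trifluoromethyl in place of methyl on an aromatic carbon. That single change gave a number 0.66 log units higher from compound 1 to compound 2 (beyond the scatter). Compound 3 carries a different group on the same kind of core; the difference between compound 1 and compound 3 is not broken down here. Among the three, compound 3 stands highest in this assay, with compound 2 the nearest to it and compound 1 the furthest.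

Compound 4, `COc1ccc(-c2c(C#N)[n+]([O-])c3cc(C(F)(F)F)ccc3[n+]2[O-])cc1`, has not yet been measured. It is related to compound 3 in the same way that compound 2 is related to compound 1: trifluoromethyl in place of methyl on an aromatic carbon. The place is described in identical words for both pairs. This is the same change, made a second time on a different partner.

Within the data shown here, the expectation for compound 4 rests on the one earlier step, a number 0.66 log units higher from compound 1 to compound 2 (beyond the scatter), taken as a guide for what the same change will do starting from compound 3. On that basis, compound 4 is expected to show a step of a number 0.66 log units higher from compound 3 to compound 4 (beyond the scatter) in this assay. The estimate for compound 4 in this assay is therefore 2.49, with a plausible range from 2.1 to 2.9.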

Compound 4, partition coefficient: 2.45
Estimate against measurement, compound 4: 0.04 log units above, and the stated range covers the measured number.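

In this assay, trifluoromethyl in place of methyl on an aromatic carbon gave a number 0.62 log units higher from compound 3 to compound 4 (beyond the scatter) and this is close in size to a number 0.66 log units higher from compound 1 to compound 2 (beyond the scatter) so, in these two pairs, the change carried over from a compound with furan-2-yl to one with 4-methoxyphenyl. Keeping trifluoromethyl and putting 4-methoxyphenyl in place of furan-2-yl gave a number 0.95 log units higher from compound 2 to compound 4 (beyond the scatter) and this is a different change, so it does not add a further test of the methyl to trifluoromethyl swap. Two pairs show agreement in this one measurement only: they do not show that the step would hold for other partners, and nothing here explains why the two steps came out so alike.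

The compounds shown carry only methyl or trifluoromethyl at this carbon, so how an amine or a carboxylic acid in that place would compare in this assay remains open. The partners shown are likewise only furan-2-yl and 4-methoxyphenyl, and whether the step keeps its size beside a partner bearing a longer chain is not settled by these four compounds.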